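Iodo to methoxy: expected loss of growth inhibition

The source may report more compounds than this note shows. Statements on the series, on what has been measured and on what is new or still open speak of the compounds shown alone.

Going by the values given here, in a functional assay on SNB-19 cells (Homo sapiens) for inhibition (on this read-out higher numbers stand for weaker inhibition of growth and lower numbers for stronger inhibition of growth), compound 1 `NC(=O)c1cc(Cl)ccc1NC(=O)COc1ccccc1` gives 11700 nM and compound 2 `NC(=O)c1cc(I)ccc1NC(=O)COc1ccccc1` gives 913 nM, the lower of the two numbers so far. Compound 3 `COc1ccc(NC(=O)COc2ccccc2)c(C(N)=O)c1` has methoxy in place of iodo on an aromatic carbon, meta to a carbamoyl group and para to a large group: methoxy in place of iodo on an aromatic carbon. Among the compounds with values here, one measured step bears on this change, a 13-fold lower number from compound 1 to compound 2 (1.11 log units; beyond the scatter), which is large and beyond the scatter. It concerns the same place on the ring and shows that the group there can shift the number strongly. Within the data shown here, no methoxy compound has been measured, so the size of the next step is uncertain. Giving up iodo is expected to lose much of the gain seen in that step, with a 6.6-fold higher number from compound 2 to compound 3 (0.82 log units; beyond the scatter) expected in this assay. For compound 3 the estimated value is 6000 nM, within an expected range of 1800 nM to 20000 nM.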

Compound 3, concentration for 50% growth inhibition: 3200 nM
Estimate against measurement, compound 3: 1.9-fold (0.27 log units) above; the range from low to high includes it.
By their numbers in this assay, from the lowest: compound 2; then compound 3; then compound 1.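

In this assay, the place on the ring accepts a non-halogen group while keeping part of the gain: a 3.5-fold higher number from compound 2 to compound 3 (0.54 log units; beyond the scatter), yet a 3.7-fold lower number from compound 1 to compound 3 (0.56 log units; beyond the scatter). Methoxy therefore falls between the two halogens, with iodo giving the lowest number of the three and chloro the highest, both gaps beyond the scatter. The gain over chloro is thus not confined to iodo, though iodo remains ahead, and nothing measured here accounts for this order.

The compounds shown leave open how an amine, a carboxylic acid or a longer chain such as ethoxy would rank against iodo at this place. They also leave open whether the order iodo, methoxy, chloro holds when the phenoxy end of the shared core carries a substituent.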